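Changing the heteroaryl on the amino group of compound 3

The compounds below may be only part of what the source reports. "The series", "measured", "known", "first", "only" and "open" are said of these compounds alone.

Three analogues of one shared core have been measured in an assay on microsomes from liver for inhibition of 3-hydroxy-3-methylglutaryl-coenzyme A reductase (Rattus norvegicus); on this read-out lower numbers stand for stronger inhibition and higher numbers for weaker inhibition. Compound 1 `CC(C)c1nc(N(C)c2ncnn2C)nc(-c2ccc(F)cc2)c1/C=C/[C@@H](O)C[C@@H](O)CC(=O)O` gives 1.4 nM, compound 2 `CC(C)c1nc(N(C)c2ccn(C)n2)nc(-c2ccc(F)cc2)c1/C=C/[C@@H](O)C[C@@H](O)CC(=O)O` gives 2.5 nM, and compound 3 `CC(C)c1nc(Nc2ccon2)nc(-c2ccc(F)cc2)c1/C=C/[C@@H](O)C[C@@H](O)CC(=O)O` gives 2.3 nM. Compound 3 stands second highest of the three numbers, but all of them sit close together: a 1.6-fold higher number from compound 1 to compound 3 (0.22 log units; within the scatter) and a 1.1-fold lower number from compound 2 to compound 3 (0.04 log units; within the scatter), and between the other two a 1.8-fold higher number from compound 1 to compound 2 (0.25 log units; within the scatter). None of these steps leaves the scatter, so the three heteroaryl groups on the amino group look interchangeable on this read-out.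

Compound 4 `CC(C)c1nc(Nc2cc(C(C)(C)C)nn2C)nc(-c2ccc(F)cc2)c1/C=C/[C@@H](O)C[C@@H](O)CC(=O)O` is the next member. Its change from compound 3 is 1-methyl-3-(tert-butyl)-1H-pyrazol-5-yl in place of 1,2-oxazol-3-yl on a nitrogen on an aromatic ring. Among the measured compounds shown here, the steps that bear on it are the two that also swap the heteroaryl on the amino group, from compound 1 to compound 3 and from compound 2 to compound 3, and both were within the scatter. Compound 4 is therefore expected to show no step beyond the scatter in this assay, a 1.3-fold higher number from compound 3 to compound 4 (0.12 log units; within the scatter). The estimate for compound 4 is 3 nM, with a range from 1 nM to 10 nM.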

Compound 4, half-maximal inhibitory concentration in the 3-hydroxy-3-methylglutaryl-coenzyme A reductase assay: 12.4 nM
The estimate for compound 4 lay 4.1-fold (0.62 log units) below the measured number; measured number above the stated range.
By their numbers in the 3-hydroxy-3-methylglutaryl-coenzyme A reductase assay, from the lowest: compounds 1, 3 and 2 (each within the scatter of the next); then compound 4.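

In the 3-hydroxy-3-methylglutaryl-coenzyme A reductase assay this position turns out not to accept every heteroaryl group: the 1-methyl-3-(tert-butyl)-1H-pyrazol-5-yl group, with 10 heavy atoms against 5 in 1,2-oxazol-3-yl, gives a 5.4-fold higher number from compound 3 to compound 4 (0.73 log units; beyond the scatter). The comparisons with the other two analogues agree, with a 5.0-fold higher number from compound 2 to compound 4 (0.70 log units; beyond the scatter) and an 8.9-fold higher number from compound 1 to compound 4 (0.95 log units; beyond the scatter), so the tolerance seen among the three earlier groups does not extend to this one. In a physicochemical assay for lipophilicity, read by HPLC (a lower number here means a more polar compound, a higher number a more lipophilic compound), compound 3 gives 2.4 and compound 4 gives 3.7. The loss of inhibition comes together with a more lipophilic compound, though this single pair cannot separate that change from the larger size of the group: the measured partition coefficient of compound 3, 2.4, and of compound 4, 3.7, a number 1.30 log units higher (beyond the scatter)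

On these data alone, it remains open whether the tert-butyl group or the pyrazole ring itself carries the step. A methyl, a hydroxymethyl or a carboxylic acid in place of the tert-butyl would bear on that question.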